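Swapping the Nitrogen Substituent: Compound 3 to Compound 4

The compounds below may be only part of what the source reports. "The series", "measured", "known", "first", "only" and "open" are said of these compounds alone.

Of the compounds shown here, three sharing one core have been measured in a functional assay on K562 cells (Homo sapiens) for cytotoxicity, read by trypan blue exclusion, with a stated time of 96 h; on this read-out higher numbers stand for weaker inhibition and lower numbers for stronger inhibition. Compound 1 `COc1ccc(CS(=O)(=O)/C=C/c2cc(OC)c(OC)cc2OC)cc1N` gives 250 nM, compound 2 `COc1cc(OC)c(/C=C/S(=O)(=O)Cc2ccc(F)c([N+](=O)[O-])c2)c(OC)c1` gives 25000 nM, and compound 3 `COC(=O)C(Nc1cc(CS(=O)(=O)/C=C/c2c(OC)cc(OC)cc2OC)ccc1OC)c1ccc(F)cc1` gives 800 nM. Compound 3 thus holds the second highest of the three numbers: compound 1 lies lower and compound 2 lies higher, and both of these gaps fall beyond the usual scatter of this assay. No two of the measured compounds differ in a single place, so no one-step comparison can be drawn from them.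

Compound 4 `COc1ccc(C(Nc2cc(CS(=O)(=O)/C=C/c3c(OC)cc(OC)cc3OC)ccc2OC)C(=O)O)cc1` has not yet been measured. It differs from compound 3 in one place: carboxy(4-methoxyphenyl)methyl in place of (4-fluorophenyl)(methoxycarbonyl)methyl on a nitrogen on an aromatic ring. The nitrogen keeps its aromatic carbon neighbour; only the group it carries changes.

Among the measured compounds shown here, the record holds no measured step resembling this change, so the expectation rests on the value of compound 3 alone, 800 nM, and on the limited size of the change. The expected step in this assay, a 3.1-fold higher number from compound 3 to compound 4 (0.49 log units; beyond the scatter), is a moderate move toward a higher number rather than none at all. Compound 4 is therefore estimated at 2500 nM, with a plausible range from 700 nM to 9000 nM.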

Compound 4, half-maximal inhibitory concentration: 15 nM
Compound 4: the middle estimate sits 170-fold (2.22 log units) above what was measured; the whole stated range lies above it.
By their numbers in this assay, from the lowest: compound 4; then compound 1; then compound 3; then compound 2.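

In this assay, among the compounds shown here, the group on a nitrogen on an aromatic ring proves able to shift the read-out strongly, which the earlier compounds could not show, since none of them differed in a single place: the swap gives a 53-fold lower number from compound 3 to compound 4 (1.73 log units; beyond the scatter). This large step comes from two groups that match in size by heavy atom count and each hold one six-membered aromatic ring of carbon only, so the outcome depends on which atoms the group carries, not on how many. The swap changes two things at once, carboxy for methoxycarbonyl and 4-methoxyphenyl for 4-fluorophenyl, and nothing on hand offers an explanation for the size of the step.

The compounds shown leave open which of these two changes carries the step, a question that carboxy paired with 4-fluorophenyl, or methoxycarbonyl paired with 4-methoxyphenyl, would settle. They also leave open how far the result depends on the carboxylic acid itself, as a primary amide or a hydroxymethyl group in its place on the same carbon would test.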